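This account rests on a few compounds, and the source may have more. Where it says the series, first, only, none or still open, it means among the compounds named here.

Compound 3 `COc1ccccc1-c1cccc2nc(Nc3cc(OC)c(OC)c(OC)c3)oc12` is the weaker of the two compounds with a full number in an assay on BAF cells for inhibition of ribosomal protein S6 kinase alpha-2 (Mus musculus); a higher number here means a weaker inhibitor, a lower number a stronger inhibitor: compound 3 gives 5700 nM. Compound 1 `COc1cc(Nc2nc3cccc(-c4c(F)cccc4OC)c3o2)cc(OC)c1OC` carries a fluoro on the aromatic ring where compound 3 has hydrogen, and in this assay compound 1 gives 2600 nM; the step of a 2.2-fold higher number from compound 1 to compound 3 (0.34 log units; beyond the scatter) is modest but beyond the scatter. Compound 2 `COc1ccc(Nc2nc3cccc(-c4c(F)cccc4OC)c3o2)cc1` reports only a limit of the assay, > 20000 nM, which is the point the limit of > 20000 nM in this assay, at which 1 of the 3 values shown sits, where one value sits.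

Compound 4 `COc1cc(Nc2nc3cccc(-c4ccccc4OC(F)(F)F)c3o2)cc(OC)c1OC` differs from compound 3 by trifluoromethyl in place of methyl on an oxygen on an aromatic ring. For the measured compounds named here, no measured step touches this oxygen, so the single step measured, from compound 1 to compound 3, says nothing direct about it. Without a precedent, the expected outcome for compound 4 is a step of a 1.1-fold higher number from compound 3 to compound 4 (0.02 log units; within the scatter), within or near the scatter. Compound 4 is therefore estimated to give 6000 nM, with a range from 2000 nM to 20000 nM.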

Compound 4, half-maximal inhibitory concentration: > 20000 nM
Compound 4: a limit, no number; the forecaster's own chance of this, stated with the estimate: 25%; at least 3.3-fold (0.52 log units) between middle value and limit.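

The methyl on this oxygen turns out not to be a free place to change: swapping it for trifluoromethyl, which turns methoxy into trifluoromethoxy, gives in this assay an at least 3.5-fold higher number from compound 3 to compound 4 (0.54 log units; beyond the scatter). The wider comparison gives an at least 7.6-fold higher number from compound 1 to compound 4 (0.88 log units; beyond the scatter), but that step also removes the fluoro, so it does not isolate the oxygen substituent. The result for compound 4 is a limit, not a number, so the true size of both steps remains unknown, and compound 4 stands at the same limit as compound 2: the limit of > 20000 nM in this assay, at which 2 of the 4 values shown sit.

The compounds shown leave open how an ethyl group, a longer chain or a plain hydroxyl at this place would read. They also leave open whether the fluoro of compound 1, added to compound 4, would change its result.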